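The source may report more compounds than this note shows. Statements on the series, on what has been measured and on what is new or still open speak of the compounds shown alone.

Measured so far in an ADME assay on the whole organism for cytotoxicity, with Artemia salina as the target, with a stated time of 24 h; on this read-out lower numbers stand for an effect already at smaller amounts and higher numbers for an effect only at larger amounts of compound:
compound 1 `COc1ccc(/C=C/C(=O)c2ccccc2NC(=O)NS(=O)(=O)c2ccc(C)cc2)cc1OC`: 12.9 ug/mL
compound 2 `Cc1ccc(S(=O)(=O)NC(=O)Nc2ccccc2C(=O)/C=C/c2ccc(O)cc2)cc1`: 24.3 ug/mL
compound 3 `COc1cc(/C=C/C(=O)c2ccccc2NC(=O)NS(=O)(=O)c2ccc(C)cc2)ccc1O`: 17.8 ug/mL

Compound 1 gives the lowest of these three numbers, yet none of them is separated from it by more than the scatter: a 1.4-fold higher number from compound 1 to compound 3 (0.14 log units; within the scatter) and a 1.9-fold higher number from compound 1 to compound 2 (0.28 log units; within the scatter). Compound 4 `Cc1ccc(S(=O)(=O)NC(=O)Nc2ccccc2C(=O)/C=C/c2ccccc2[N+](=O)[O-])cc1` has not yet been measured. It differs from compound 1 in one place: 2-nitrophenyl in place of 3,4-dimethoxyphenyl on a double-bonded chain carbon bound to a double-bonded chain carbon. The measured step from compound 1 to compound 2 changes the same position, and the step from compound 1 to compound 3 also alters that group, and both stayed within the scatter. Therefore no step beyond the scatter is expected in this assay in either direction. Compound 4 is expected to give about 15 ug/mL, likely between 7 ug/mL and 32 ug/mL, which would mean an expected step of a 1.2-fold higher number from compound 1 to compound 4 (0.07 log units; within the scatter).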

Compound 4, concentration for half-maximal effect: 40.1 ug/mL
Estimate against measurement, compound 4: 2.7-fold (0.43 log units) below; measured number above the stated range.
By their numbers in this assay, from the lowest: compounds 1, 3, 2 and 4 (each within the scatter of the next, the first and the last beyond it).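

In this assay, for the compounds shown here, this position can move the number beyond the scatter, which no earlier step showed: 2-nitrophenyl gives a 3.1-fold higher number from compound 1 to compound 4 (0.49 log units; beyond the scatter) and a 2.3-fold higher number from compound 3 to compound 4 (0.35 log units; beyond the scatter) on the same core. Against the 4-hydroxyphenyl of compound 2, the same group gives a 1.7-fold higher number from compound 2 to compound 4 (0.22 log units; within the scatter) and stays within the scatter, so the size of the step depends on which group leaves. Nothing measured here explains these steps. The compounds shown leave open how an amine or a carboxylic acid on this aromatic ring would behave in place of the nitro group.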